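Swapping an aryl group on the triazole of a hydroxamic acid

The source may hold more compounds than are shown below. What is called first, only, known or untested is meant among the compounds shown, and "the series" means these compounds.

Compound 1 `CCc1ccc(-c2nc(CNc3ccc(C(=O)NO)cc3)n(-c3ccccc3)n2)cc1`: 54.6%
Compound 2 `O=C(NO)c1ccc(NCc2nc(-c3ccccc3)nn2-c2ccc(Cl)cc2)cc1`: 55.4%
Compound 3 `CCc1ccc(-n2nc(-c3ccccc3)nc2CNc2ccc(C(=O)NO)cc2)cc1`: 38.3%

In an assay on Sf9 cells for inhibition of protein deacetylase HDAC6 (Homo sapiens), read by fluorescence, with a stated time of 40 min, tested at 100 nM (a higher number here means more inhibition at the concentration tested (going by the name of the read-out), a lower number less inhibition), compound 1 gives 54.6%, the second highest of the three numbers, within the scatter of compound 2 and beyond the scatter above compound 3. Compound 4 `O=C(NO)c1ccc(NCc2nc(-c3ccncc3)nn2-c2ccccc2)cc1` differs from compound 1 in one place: pyridin-4-yl in place of 4-ethylphenyl on an aromatic carbon. Among the compounds with values here, the only measured step, a number 17.1 percentage points lower from compound 2 to compound 3 (beyond the scatter), concerns the aryl group on the ring nitrogen, not the aromatic carbon between two ring nitrogen atoms, so it does not bear on this change. Within the data shown here, with no step of the same kind measured, compound 4 is expected to stay near compound 1, with a step of a number 6.6 percentage points lower from compound 1 to compound 4 (within the scatter) that lies within the scatter, and an estimated value of 48% (range 30% to 65%).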

Compound 4, a percentage reported as inhibition, at one concentration (the size of the read-out at that concentration, not a potency): 30.8%
Compound 4: the middle estimate sits 17.2 percentage points above what was measured; measured number inside the range.
By their numbers in this assay, from the lowest: compounds 4 and 3 (each within the scatter of the next); then compounds 1 and 2 (each within the scatter of the next).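

Pyridin-4-yl in place of 4-ethylphenyl gives a number 23.8 percentage points lower from compound 1 to compound 4 (beyond the scatter) in this assay, the first measured sign that the group on this aromatic carbon matters, since the earlier step concerned only the aryl group on the ring nitrogen. No evidence at hand accounts for this drop.

The change swaps a ring carbon for a ring nitrogen and also removes the ethyl, so the compounds shown do not separate the two. Also open, as far as these compounds go, is how pyridin-3-yl, or a phenyl ring carrying an amine or a carboxylic acid, would read at this position.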